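Swapping the oxazole on a fluoropyrimidine sulfonamide

The compounds below may be only part of what the source reports. "The series", "measured", "known", "first", "only" and "open" are said of these compounds alone.

Values so far in a physicochemical assay for solubility; a lower number here means a less soluble compound, a higher number a more soluble compound:
Compound 1 `Cc1nc(-c2cc(C(F)(F)F)ccc2[C@H]2CCOc3cc(S(=O)(=O)Nc4cccc(F)n4)ccc32)co1` gives 13000 nM
Compound 2 `Cc1nc(-c2cc(C(F)(F)F)ccc2[C@H]2CCOc3cc(S(=O)(=O)Nc4ncc(F)cn4)ccc32)co1` gives 281000 nM
Compound 3 `O=C1OCCN1c1cc(C(F)(F)F)ccc1[C@H]1CCOc2cc(S(=O)(=O)Nc3nccs3)ccc21` gives 295000 nM

Compound 2 stands at the high end of these numbers together with compound 3, the two values lying within the scatter of each other, while compound 1 sits far lower. Compound 4 `Cc1ccc(-c2cc(C(F)(F)F)ccc2[C@H]2CCOc3cc(S(=O)(=O)Nc4ncc(F)cn4)ccc32)cn1` departs from compound 2 in one group: 6-methylpyridin-3-yl in place of 2-methyl-1,3-oxazol-4-yl on an aromatic carbon. The 6-methylpyridin-3-yl enters in place of 2-methyl-1,3-oxazol-4-yl on an aromatic carbon, ortho to a large group and meta to a trifluoromethyl group.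

For the measured compounds named here, the one measured step between compounds differing in a single place, a 22-fold higher number from compound 1 to compound 2 (1.33 log units; beyond the scatter), was large, but it lies at the sulfonamide nitrogen and not at this aromatic carbon. It bears only indirectly, showing that one group change in this series can move this assay well beyond the scatter. Compound 3 differs from compound 2 in more than one place and isolates nothing. With compound 2 at 281000 nM, the high end of the measured span, a moderate step to a lower number is the loose expectation. Going by the values given here, the estimated step is a 2.3-fold lower number from compound 2 to compound 4 (0.37 log units; beyond the scatter), though no measured step covers this change. For compound 4 the expected value is 120000 nM, with an estimated range from 30000 nM to 400000 nM.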

Compound 4, solubility: 225000 nM
The estimate for compound 4 lay 1.9-fold (0.27 log units) below the measured number; measured number inside the range.
By their numbers in this assay, from the lowest: compound 1; then compounds 4, 2 and 3 (each within the scatter of the next).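

In this assay, for the compounds shown here, putting 6-methylpyridin-3-yl in place of 2-methyl-1,3-oxazol-4-yl on the aromatic carbon, ortho to a large group and meta to a trifluoromethyl group, gives a 1.2-fold lower number from compound 2 to compound 4 (0.10 log units; within the scatter), the only measured step at this position, and it leaves the two compounds indistinguishable in this read-out. With the 5-fluoropyrimidin-2-yl group held fixed on the sulfonamide nitrogen, a five-membered aromatic ring with 2 hetero atoms and a six-membered aromatic ring with 1 hetero atom therefore read alike here, whereas the single-place step at the sulfonamide nitrogen was a 22-fold higher number from compound 1 to compound 2 (1.33 log units; beyond the scatter). No measurement offered here accounts for the two aromatic groups reading alike.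

The compounds shown leave open whether this holds for groups of another kind on the same aromatic carbon, such as an aliphatic amine, a carboxylic acid or a longer alkyl chain. On these data alone, it is also open whether the same exchange of aromatic rings would read alike with the 6-fluoropyridin-2-yl group on the sulfonamide nitrogen, the group carried by compound 1 at 13000 nM.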